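Bromoacrylamide removal on the thiazolidinedione series

This account rests on a few compounds, and the source may have more. Where it says the series, first, only, none or still open, it means among the compounds named here.

Two compounds have numbers in a functional assay on FM3A cells (Mus musculus) for cytotoxicity, read by cell counting, with a stated time of 2 days; a lower number here means a stronger inhibitor, a higher number a weaker inhibitor. Compound 1 `CC(C)(C)c1ccc(CN2C(=O)S/C(=C\c3cccc(N)c3)C2=O)cc1` gives 188000 nM. Compound 2 `C=C(Br)C(=O)Nc1cccc(/C=C2\SC(=O)N(Cc3ccc(C(F)(F)F)cc3)C2=O)c1` gives 870 nM. Going by the values given here, compound 2 therefore stands at the lower of the two numbers, with compound 1 its only neighbour at a markedly higher number, a gap beyond the usual scatter.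

Compound 3 `Nc1cccc(/C=C2\SC(=O)N(Cc3ccc(C(F)(F)F)cc3)C2=O)c1` is the next member to be measured in this assay. It is derived from compound 2 by hydrogen in place of (1-bromoethenyl)carbonyl on a nitrogen on an aromatic ring, which leaves the free amino group on the aromatic ring. Among the compounds with values here, no pair of measured compounds shows this change directly. Compound 1 does carry the same free amino group, differing from compound 3 only in the substituent on the benzyl group (tert-butyl against trifluoromethyl), and its number lies far above that of compound 2.

On that basis a large loss is expected for the step from compound 2 to compound 3, a 110-fold higher number from compound 2 to compound 3 (2.06 log units; beyond the scatter), well beyond the scatter. Compound 3 is accordingly estimated at 100000 nM, with a range of 20000 nM to 300000 nM.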

Compound 3, half-maximal inhibitory concentration: > 250000 nM
Compound 3 gave a limit, no number (the forecaster's own chance of this, stated with the estimate: 25%); at least 2.5-fold (0.39 log units) between middle value and limit.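

In this assay, compound 3 stands at a limit of the assay and not at a number: the limit of > 250000 nM in this assay, at which 1 of the 3 values shown sits.

The direct change on the nitrogen, ((1-bromoethenyl)carbonyl)amino to amino, gives an at least 280-fold higher number from compound 2 to compound 3 (2.45 log units; beyond the scatter), a large step whose size is only a floor, and it ties the measurable number in this pair to the group on that nitrogen. With the free amino group in place, trifluoromethyl in place of tert-butyl reads an at least 1.3-fold higher number from compound 1 to compound 3 (0.12 log units; that floor lies within the scatter), so this pair does not separate the two benzyl substituents and shows no gain or loss from that change.

The compounds shown leave open whether the bromine is needed or whether the carbonyl on the nitrogen is enough, a question that a plain acetyl amide or an acryloyl amide without bromine on the same nitrogen would address. Going by these compounds alone, also open is whether tert-butyl and trifluoromethyl differ when the (1-bromoethenyl)carbonyl group is kept, as the only comparison of these two substituents here carries the free amino group and rests on a limit.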